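The source may report more compounds than this note shows. Statements on the series, on what has been measured and on what is new or still open speak of the compounds shown alone.

Compound 1 `O=C1NC(=O)C(Cc2ccc(OCC3CCCCO3)cc2)S1`: > 100000 nM
Compound 2 `CCC(C)(C)Oc1ccc(CC2SC(=O)NC2=O)cc1`: 23000 nM
Compound 3 `CCOc1ccc(CC2SC(=O)NC2=O)cc1`: > 100000 nM

These three compounds were tested in a functional assay on PC-12 cells (Rattus norvegicus) for inhibition, read by sulforhodamine B assay; a lower number here means a stronger inhibitor, a higher number a weaker inhibitor. Compound 3, which carries an ethyl group on the oxygen on the aromatic ring, reads > 100000 nM, and this is a limit of the assay and not a number. Compound 1 sits in the same place, and the reference point for both is the limit of > 100000 nM in this assay, at which 2 of the 3 values shown sit.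

Compound 4 `O=C1NC(=O)C(Cc2ccc(OCc3ccccc3)cc2)S1` has not yet been measured. It has phenyl in place of methyl on a saturated chain carbon bound to an oxygen on an aromatic ring, so that ethyl becomes benzyl: phenyl in place of methyl on a saturated chain carbon bound to an oxygen on an aromatic ring.

The nearest measured change is a step that the two limits leave unreadable from compound 1 to compound 3, with methyl in place of oxan-2-yl at that same place. It gives no size to carry over. The other two steps both involve the 1,1-dimethylpropyl group of compound 2: an at least 4.3-fold lower number from compound 1 to compound 2 (0.63 log units; beyond the scatter) and an at least 4.3-fold higher number from compound 2 to compound 3 (0.63 log units; beyond the scatter). They show that the group on this oxygen can matter, although a larger group does not always help, as compound 1 shows. In this assay, a modest move to a lower number is therefore expected, and the reading may well stay at the limit. The expected change is an at least 1.6-fold lower number from compound 3 to compound 4 (0.22 log units; that floor lies within the scatter). For compound 4 the estimated value is 60000 nM, with an expected range from 20000 nM to 150000 nM.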

Compound 4, half-maximal inhibitory concentration: > 100000 nM
Compound 4 was reported as a limit; the forecaster's own chance of this, stated with the estimate: 45%; middle value at least 1.6-fold (0.22 log units) away from the limit.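

In this assay, the change from ethyl to benzyl did not lift compound 4 off the limit, which is a limit of the assay and not a number, so adding a phenyl on this saturated chain carbon bound to an oxygen on an aromatic ring gave no readable gain: the limit of > 100000 nM in this assay, at which 3 of the 4 values shown sit. The steps from compound 3 to compound 4 and from compound 1 to compound 4 cannot be read, since both ends of each are limits. For the compounds shown here, the one readable step is an at least 4.3-fold higher number from compound 2 to compound 4 (0.63 log units; beyond the scatter), which leaves compound 2, with its 1,1-dimethylpropyl group, as the only one of the four with a measured number, while the ring-bearing groups of compound 1 and compound 4 stay at the limit alongside the ring-free ethyl of compound 3.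

The compounds shown leave open how compound 1, compound 3 and compound 4 rank beyond the limit, and whether the effect of 1,1-dimethylpropyl is particular to that group. A tert-butyl group on the same oxygen, or an amine or a carboxylic acid on the phenyl of the benzyl group, would be untested here.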